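The compounds below may be only part of what the source reports. "The series", "measured", "known", "first", "only" and "open" are said of these compounds alone.

Measured compounds:
compound 1 `CN(CCCc1ccccc1)Cc1cn(C2CCCCC2OC(=O)COc2ccccc2)nn1`: 42%
compound 2 `CC(C)CCN(C)Cc1cn(CC(O)COC(=O)NCc2ccccc2)nn1`: 26%
compound 3 `CCCCCCCC(=O)OCC(O)Cn1cc(CN2CCN(c3ccccc3)CC2)nn1`: 26%

In an assay on nucleic acid for inhibition of Nucleic Acid, read by fluorescence, tested at 100 uM (a lower number here means less inhibition, a higher number more inhibition at the concentration tested (going by the name of the read-out)), compound 3 gives 26%, level with compound 2 at the digits shown, and the two together stand lowest of the three numbers; compound 1 sits higher, and that gap lies beyond the scatter. Compound 4 `CCCCC(O)Cn1cc(CN2CCN(c3ccccc3)CC2)nn1` has not yet been measured. It differs from compound 3 in one place: propyl in place of (heptylcarbonyl)oxy on a saturated chain carbon, two bonds along the chain from an oxygen on a saturated carbon. Among the measured compounds shown here, no step between measured compounds that differ in a single place is known, so the expectation rests on compound 3 alone. With compound 3 at 26%, the step of a number 4 percentage points lower from compound 3 to compound 4 (within the scatter) is expected to be small, if anything downward, and probably within the scatter. Compound 4 is expected to give 22% in this assay, with a range from 8% to 40%.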

Compound 4, a percentage reported as inhibition, at one concentration (the size of the read-out at that concentration, not a potency): 47%
Beside the measured number, compound 4's estimate is 25 percentage points below it; measured number above the stated range.
By their numbers in this assay, from the lowest: compounds 2 and 3 (each within the scatter of the next); then compounds 1 and 4 (each within the scatter of the next).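

In this assay, putting propyl in place of (heptylcarbonyl)oxy on a saturated chain carbon, two bonds along the chain from an oxygen on a saturated carbon, gives a number 21 percentage points higher from compound 3 to compound 4 (beyond the scatter) and shows that the number responds to a change at this position. The long acyloxy group is therefore not required for the inhibition seen at the concentration tested. Nothing available here accounts for the step.

The compounds shown do not separate the length of the chain from the loss of the carbonyl and its oxygens. An octyl chain or a shorter butanoyloxy group at this place would pull those two apart.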